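Swapping a sulfone for a trifluoromethyl sulfide

The compounds below may be only part of what the source reports. "The series", "measured", "known", "first", "only" and "open" are said of these compounds alone.

Three compounds share one amide core and differ only in the sulfur-bearing group on the far ring. In an assay on HeLa cells with Bile acid receptor (Homo sapiens) as the target, read by a luciferase reporter, with a stated time of 24 h (on this read-out lower numbers stand for an effect already at smaller amounts and higher numbers for an effect only at larger amounts of compound), compound 2 `CSc1ccc(CNC(=O)c2ccc(C(C)(C)C)cc2)cc1` gives 100 nM, compound 1 `C[S+]([O-])c1ccc(CNC(=O)c2ccc(C(C)(C)C)cc2)cc1` gives 1300 nM, and compound 3 `CC(C)(C)c1ccc(C(=O)NCc2ccc(S(C)(=O)=O)cc2)cc1` gives 3800 nM, the highest number of the three. The steps are large: a 13-fold lower number from compound 1 to compound 2 (1.11 log units; beyond the scatter), a 2.9-fold higher number from compound 1 to compound 3 (0.47 log units; beyond the scatter), and a 38-fold higher number from compound 2 to compound 3 (1.58 log units; beyond the scatter).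

Compound 4 `CC(C)(C)c1ccc(C(=O)NCc2ccc(SC(F)(F)F)cc2)cc1` has not yet been measured in this assay. The change from compound 3 is (trifluoromethyl)sulfanyl in place of methylsulfonyl on an aromatic carbon; the sulfur thus loses its two oxygens and carries a trifluoromethyl instead of a methyl. The most telling measured step is a 38-fold higher number from compound 2 to compound 3 (1.58 log units; beyond the scatter), which runs in the opposite direction to the present change and shows that removing the two oxygens from the sulfur is linked to a large drop in the number. Among the measured compounds shown here, compound 4 returns to a sulfide as in compound 2, so a large step down from compound 3 is expected, with some uncertainty from the trifluoromethyl, for which no measured step exists.

For compound 4 the number in this assay is estimated at 150 nM, between 40 nM and 800 nM, which is an expected step of a 25-fold lower number from compound 3 to compound 4 (1.40 log units; beyond the scatter).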

Compound 4, half-maximal effective concentration: 0.4 nM
Estimate against measurement, compound 4: 380-fold (2.57 log units) above; the measured number lies below the stated range.
By their numbers in this assay, from the lowest: compound 4; then compound 2; then compound 1; then compound 3.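

In this assay, among the compounds shown here, the earlier compounds pointed only to the oxygens on the sulfur, but changing nothing except the methyl on the sulfur to trifluoromethyl gives a 250-fold lower number from compound 2 to compound 4 (2.40 log units; beyond the scatter), so what the sulfur carries matters here as well. For the compounds shown here, the sulfide with a methyl therefore does not mark the lowest number reachable at this position on the far ring: the (trifluoromethyl)sulfanyl group gives a 9500-fold lower number from compound 3 to compound 4 (3.98 log units; beyond the scatter) against the methylsulfonyl group and a 3300-fold lower number from compound 1 to compound 4 (3.51 log units; beyond the scatter) against the group with a single oxygen on the sulfur, both larger than any step among the earlier compounds. No measurement available here explains why the trifluoromethyl has so large an effect.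

The compounds shown leave open whether the gain depends on the sulfur at all, which a trifluoromethyl or a trifluoromethoxy group on the same ring carbon could test. They also leave open how a difluoromethyl on the sulfur would compare, and whether a trifluoromethyl would give the same gain on a sulfur that carries oxygens.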